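This account rests on a few compounds, and the source may have more. Where it says the series, first, only, none or still open, it means among the compounds named here.

Measured so far in an ADME assay on Vero cells (Chlorocebus sabaeus) for cytotoxicity, read by fluorescence and resazurin assay, with a stated time of 3 days; a higher number here means that more compound is tolerated, a lower number that less compound is tolerated:

Compound 1 `C=CCn1cc(CCCC(=O)NC2CCCCCC2)c2ccccc21`: "not determined" (no result reported).
Compound 2 `CC(C)(C)c1ccc(S(=O)(=O)n2cc(CCCC(=O)NC3CCCCCC3)c3ccccc32)cc1`: > 250000 nM, a limit.
Compound 3 `O=C(CCCc1cn(S(=O)(=O)c2cccc3ccccc23)c2ccccc12)NC1CCCCCC1`: > 250000 nM, a limit.

Compound 3 has no exact number in this assay: its entry of > 250000 nM is a limit. Compound 2 also stands at a limit, > 250000 nM. Compound 1 has no reported result and adds nothing to the comparison.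

The next compound is compound 4 `Cc1cc(S(=O)(=O)n2cc(CCCC(=O)NC3CCCCCC3)c3ccccc32)c(C)cc1Cl`, which differs from compound 3 on a sulfonyl sulfur: 4-chloro-2,5-dimethylphenyl in place of naphthalen-1-yl on a sulfonyl sulfur. Going by the values given here, one measured step bears on this place, a step that the two limits leave unreadable from compound 2 to compound 3, and there naphthalen-1-yl took the place of 4-(tert-butyl)phenyl. Both ends of that step are limits and it has no readable size. The only firm observation is the limit of > 250000 nM in this assay, at which 2 of the 3 values shown sit. Neither group on the sulfonyl sulfur has yet given a measured number, so no direction can be drawn from these data, and no step beyond the scatter is expected in this assay. The expected change is an at least 1.1-fold lower number from compound 3 to compound 4 (0.05 log units; that floor lies within the scatter). For compound 4 the estimate is 220000 nM, with an expected range from 80000 nM to 300000 nM.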

Compound 4, half-maximal cytotoxic concentration: > 250000 nM
Compound 4: only a limit was reported; the forecaster's own chance of this, stated with the estimate: 70%; at least 1.1-fold (0.05 log units) between middle value and limit.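

In this assay compound 4 gives > 250000 nM, which is a limit. Its steps from compound 2 and from compound 3 cannot be read, as all three entries are limits: the limit of > 250000 nM in this assay, at which 3 of the 4 values shown sit.

The compounds shown leave open whether 4-(tert-butyl)phenyl, naphthalen-1-yl and 4-chloro-2,5-dimethylphenyl on the sulfonyl sulfur differ at all in the concentration tolerated.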